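The source may report more compounds than this note shows. Statements on the series, on what has been measured and on what is new or still open speak of the compounds shown alone.

Compound 1 `CN1CCN(CCCCn2c3c(c4ccccc42)C(=O)c2c[n+]([O-])c4ccccc4c2C3=O)CC1` gives 10 nM in a functional assay on HCT-116 cells (Homo sapiens) for cytotoxicity, read by MTT assay, with a stated time of 72 h (a higher number here means a weaker inhibitor, a lower number a stronger inhibitor), the lowest of the three numbers in hand. Compound 2 `CC1(C)O[C@@H](CO)[C@H](Cn2cc(Cn3c4c(c5ccccc53)C(=O)c3c[n+]([O-])c5ccccc5c3C4=O)nn2)O1` gives 130 nM and compound 3 `CC1(C)OC[C@H](Cn2cc(Cn3c4c(c5ccccc53)C(=O)c3c[n+]([O-])c5ccccc5c3C4=O)nn2)O1` gives 130 nM, both well above compound 1. For the measured compounds named here, the only single-site step measured, no change at the digits printed from compound 2 to compound 3 (within the scatter), concerns a saturated ring carbon on the side group and says nothing about the chain or amine attached to the core nitrogen. Compound 4 `O=C1c2c[n+]([O-])c3ccccc3c2C(=O)c2c1c1ccccc1n2CCCN1CCC(O)CC1` differs from compound 1 by 4-hydroxypiperidin-1-yl in place of (4-methylpiperazin-1-yl)methyl on a saturated chain carbon, three bonds along the chain from an aromatic nitrogen. Going by the values given here, no measured step bears on this change; the basic amine end of the chain is kept, so no move beyond the scatter is expected, a 1.5-fold higher number from compound 1 to compound 4 (0.18 log units; within the scatter). Compound 4 is estimated at 15 nM, with a range of 5 nM to 50 nM.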

Compound 4, half-maximal inhibitory concentration: 190 nM
Estimate against measurement, compound 4: 13-fold (1.10 log units) below; the whole stated range lies below it.
By their numbers in this assay, from the lowest: compound 1; then compounds 2, 3 and 4 (each within the scatter of the next).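

For the compounds shown here, the chain end on the core nitrogen is not a silent position in this assay: a 19-fold higher number from compound 1 to compound 4 (1.28 log units; beyond the scatter), a large step at a place no earlier step touched. The change swaps the ring end and shortens the chain in one move, 4-(4-methylpiperazin-1-yl)butyl to 3-(4-hydroxypiperidin-1-yl)propyl, so the step belongs to the pair of changes together. Nothing at hand accounts for its size.

The compounds shown leave open how the step divides between ring and chain length. A 3-(4-methylpiperazin-1-yl)propyl or 4-(4-hydroxypiperidin-1-yl)butyl chain on the same core would separate the two.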